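Solubility notes: aryl replacement on the trifluoromethyl-bearing ring

The source may report more compounds than this note shows. Statements on the series, on what has been measured and on what is new or still open speak of the compounds shown alone.

Measured so far:
compound 1 `O=c1ncn(Cc2c(F)cc(F)cc2F)c2ccc(Oc3cccc(-c4ccc5[nH]cnc5c4)c3C(F)(F)F)cc12`: < 0.1 ug/mL
compound 2 `O=c1ncn(Cc2c(F)cc(F)cc2F)c2ccc(Oc3cccc(-c4ccc5cc[nH]c5c4)c3C(F)(F)F)cc12`: < 0.1 ug/mL

In a physicochemical assay for solubility, using the shake flask method, with a stated time of 24 h, at pH 6.8 (on this read-out lower numbers stand for lower solubility and higher numbers for higher solubility), compound 1 gives < 0.1 ug/mL, which is a limit of the assay and not a number. In this assay compound 2 gives < 0.1 ug/mL, again only a limit. For the measured compounds named here, the single measured step, a step that the two limits leave unreadable from compound 1 to compound 2, cannot be sized because of the limit of < 0.1 ug/mL in this assay, at which 2 of the 2 values shown sit. Compound 2 therefore stands at the floor of this assay, and nothing in the numbers separates it from compound 1.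

Compound 3 `Cc1ccc(-c2cccc(Oc3ccc4c(c3)c(=O)ncn4Cc3c(F)cc(F)cc3F)c2C(F)(F)F)cn1` differs from compound 2 as follows: 6-methylpyridin-3-yl in place of 1H-indol-6-yl on an aromatic carbon. Going by the values given here, no measured step bears on this change, and the one step available is unreadable, so no size or direction in this assay can be drawn from it. The working expectation is that compound 3 stays close to the floor, with some chance of a readable number. Compound 3 is expected to give 0.3 ug/mL, between 0.05 ug/mL and 2 ug/mL. The expected step is an at least 3.0-fold higher number from compound 2 to compound 3 (0.47 log units; beyond the scatter).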

Compound 3, solubility: < 0.1 ug/mL
Compound 3: a limit, no number; the forecaster's own chance of this, stated with the estimate: 45%; middle value at least 3.0-fold (0.47 log units) from the limit.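

In this assay compound 3 gives < 0.1 ug/mL, a limit and not a number. For the compounds shown here, no step among compound 1, compound 2 and compound 3 can be read, because all three values are the same limit: the limit of < 0.1 ug/mL in this assay, at which 3 of the 3 values shown sit. The compounds shown leave open whether these three aryl groups differ at all on this read-out.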